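The source may report more compounds than this note shows. Statements on the series, on what has been measured and on what is new or still open speak of the compounds shown alone.

Measured compounds in this series:

compound 1, `C=CC1=C(C(=O)NCc2ccc(Cl)cc2)C(c2ccc(F)cc2)OC1`, > 100000 nM
compound 2, `C=CC1=C(C(=O)NC2CCCCC2)C(c2ccc(OC)c(OC)c2)OC1`, 5540 nM

In a functional assay on HeLa cells (Homo sapiens) for cytotoxicity, read by MTT assay, with a stated time of 24 h (a higher number here means a weaker inhibitor, a lower number a stronger inhibitor), compound 1 gives only a limit, > 100000 nM; no number is recorded for it, and the limit of > 100000 nM in this assay, at which 1 of the 2 values shown sits, applies. Compound 2, `C=CC1=C(C(=O)NC2CCCCC2)C(c2ccc(OC)c(OC)c2)OC1`, gives 5540 nM in this assay. Among the compounds with values here, the two compounds differ in more than one place, so their values show only that compound 2 has a measured value where compound 1 has none.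

Compound 3, `C=CC1=C(C(=O)Nc2ccc(C)cc2)C(c2ccc(F)cc2)OC1`, is not yet measured. It differs from compound 1 in one place: 4-methylphenyl in place of 4-chlorobenzyl on an amide-type nitrogen. The shared core and the 4-fluorophenyl group are kept.

Within the data shown here, no measured pair differs in this way, so there is nothing that shows what exchanging 4-chlorobenzyl for 4-methylphenyl on the amide nitrogen does. Compound 1 itself stands at a limit, which leaves the size of any step open. Compound 3 is expected to stay weak, and the step from compound 1 to compound 3 is estimated as an at least 1.2-fold lower number from compound 1 to compound 3 (0.09 log units; that floor lies within the scatter), with a fair chance that this assay again reports only a limit. The estimate for compound 3 is 80000 nM, within 20000 nM to 300000 nM.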

Compound 3, half-maximal inhibitory concentration: > 100000 nM
Compound 3: no number, only a limit; the forecaster's own chance of this, stated with the estimate: 50%; middle value at least 1.2-fold (0.09 log units) away from the limit.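

Compound 1 and compound 3 both give only a limit in this assay, so no step between them can be read; the value concerned is: the limit of > 100000 nM in this assay, at which 2 of the 3 values shown sit.

Still open, going by these compounds, is how far 4-methylphenyl in place of 4-chlorobenzyl on the amide nitrogen moves the value, and which of the differences between compound 1 and compound 2 goes with the measured value of compound 2.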